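Inverting both stereocentres of compound 3: clearance expectation

The source may hold more compounds than are shown below. What is called first, only, known or untested is meant among the compounds shown, and "the series" means these compounds.

Measured in an ADME assay on cells (Hepatocyte, Rattus norvegicus, strain Wistar) for pharmacokinetics, read by LC-MS, with a stated time of 90 min, tested at 1 uM; on this read-out higher numbers stand for fast clearance and lower numbers for slow clearance:
- compound 1 `COc1cc(C(=O)N2CCCC2(C)C)cc2nc(NCc3cccc(Cl)c3)oc12`: 58.3 mL/min/kg
- compound 2 `COc1cc(C(=O)N2CCC(O)CC2)cc2nc(NCc3cccc(Cl)c3)oc12`: 21.7 mL/min/kg
- compound 3 `COc1cc(C(=O)N2CC[C@@H](O)[C@H](C)C2)cc2nc(NCc3cccc(Cl)c3)oc12`: 38.3 mL/min/kg

Compound 3 is second highest of the three numbers, but it lies within the scatter of both other compounds. Only the outer pair is resolved, by a 2.7-fold lower number from compound 1 to compound 2 (0.43 log units; beyond the scatter).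

Compound 4 `COc1cc(C(=O)N2CC[C@H](O)[C@@H](C)C2)cc2nc(NCc3cccc(Cl)c3)oc12` has the same atoms and bonds as compound 3: the two compounds have the same atoms and bonds and differ only in configuration as drawn: 2 of 2 stereo elements differ (all stereocentres are inverted: mirror images); a stereocentre at a saturated ring carbon is drawn R in compound 3 and S in compound 4; a stereocentre at a saturated ring carbon is drawn R in compound 3 and S in compound 4. The two are mirror images.

No measured pair separates mirror images, so the size of this step is not shown directly. The closest evidence is a 1.8-fold higher number from compound 2 to compound 3 (0.25 log units; within the scatter), which adds the methyl, and a 1.5-fold lower number from compound 1 to compound 3 (0.18 log units; within the scatter). Neither exceeds the scatter, and neither concerns configuration.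

The expected change is a 1.1-fold lower number from compound 3 to compound 4 (0.04 log units; within the scatter), with no clear direction and no step beyond the scatter anticipated. The estimate for compound 4 is 35 mL/min/kg, with an expected range from 19 mL/min/kg to 62 mL/min/kg in this assay.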

Compound 4, clearance: 36.7 mL/min/kg
For compound 4 the middle estimate is 1.0-fold (0.02 log units) below the measured one, and the stated range covers the measured number.
By their numbers in this assay, from the lowest: compounds 2, 4, 3 and 1 (each within the scatter of the next, the first and the last beyond it).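

Inverting both stereocentres of the 4-hydroxy-3-methylpiperidin-1-yl group leaves the clearance unresolved in this assay, with a 1.0-fold lower number from compound 3 to compound 4 (0.02 log units; within the scatter), and this gives the first direct reading of configuration at this position, with nothing else varying: the fact that compounds 3 and 4 differ only in the configuration as drawn. The methyl comparison now stands for both mirror images and stays within the scatter, with a 1.7-fold higher number from compound 2 to compound 4 (0.23 log units; within the scatter), as does the exchange with 2,2-dimethylpyrrolidin-1-yl, with a 1.6-fold lower number from compound 1 to compound 4 (0.20 log units; within the scatter). Going by these compounds alone, compound 1 and compound 2 therefore remain the only resolved pair, and neither mirror image can be separated from either of them.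

The other relative arrangement of the hydroxy and methyl groups remains open, since only one pair of mirror images is shown. Also open, going by these compounds, is whether an amine or a carboxylic acid in place of the hydroxy would give a step beyond the scatter.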